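This account rests on a few compounds, and the source may have more. Where it says the series, first, only, none or still open, it means among the compounds named here.

Measured compounds:
compound 1 `Cc1cc(-c2sc(Cc3cccc(N(C)C)c3)nc2C)ccc1C(N)=O` — 690 nM in a functional assay on cells for agonist activity at G-protein coupled receptor 52 (Homo sapiens), read by AlphaScreen and cAMP accumulation, with a stated time of 30 min; a higher number here means that more compound is needed for the effect, a lower number that less compound is needed
compound 2 `Cc1cc(-c2sc(Cc3cccc(F)c3)nc2C)ccc1C(N)=O` — 260 nM in this assay

Going by the values given here, compound 2 holds the lowest of the two numbers so far; compound 1 sits above it by a 2.7-fold lower number from compound 1 to compound 2 (0.42 log units; beyond the scatter). Compound 3 `Cc1cc(-c2sc(Cc3cc(F)cc(Cl)c3)nc2C)ccc1C(N)=O` differs from compound 2 by chloro in place of hydrogen on an aromatic carbon. Among the compounds with values here, the only measured step concerns a different exchange, fluoro for dimethylamino, so nothing measured here speaks directly to adding a chloro. Without such a precedent, compound 3 is expected to land close to compound 2, with a step in this assay of a 1.3-fold lower number from compound 2 to compound 3 (0.11 log units; within the scatter) that may well stay within the scatter. Compound 3 is therefore estimated at 200 nM, within 70 nM to 600 nM.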

Compound 3, half-maximal effective concentration: 25 nM
The estimate for compound 3 lay 8.0-fold (0.90 log units) above the measured number, outside the stated range (below it).
By their numbers in this assay, from the lowest: compound 3; then compound 2; then compound 1.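

Adding a chloro, which turns the 3-fluorophenyl into the 3-chloro-5-fluorophenyl, gives a 10-fold lower number from compound 2 to compound 3 (1.02 log units; beyond the scatter) in this assay. The earlier step exchanged one group for another at a different place on this ring, whereas this one shows that a single added heavy atom, meta to a fluoro group, can change the number by a large step. Nothing available explains the size of this step.

The compounds shown leave open whether a methyl, a methoxy or a nitrile at this place would give a similar step. They also leave open whether the chloro would give such a step without the fluoro group.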